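Cytotoxicity notes on the phenol series, compounds 1 to 3

The compounds below may be only part of what the source reports. "The series", "measured", "known", "first", "only" and "open" are said of these compounds alone.

The shared core is the chain-substituted phenol of compound 1 `C=C[C@@](C)(/C=C/c1ccc(O)cc1)CCCO`. In a functional assay on SEM cells (Homo sapiens) for cytotoxicity, with a stated time of 72 h (a higher number here means that more compound is needed for the effect, a lower number that less compound is needed), compound 1 reports only a limit, > 36600 nM, and no number. Compound 2 `C=C[C@@](C)(/C=C/c1ccc(O)c(/C=C/C(=O)OCc2ccccc2)c1)CCC=C(C)C` adds a benzyloxycarbonyl-bearing double-bonded chain to the ring and carries the longer branched chain. In this assay compound 2 also gives a limit, > 36600 nM, not a number. Compound 2 thus stands at the limit of > 36600 nM in this assay, at which 2 of the 2 values shown sit, the same place as the other value shown. Among the measured compounds shown here, no step between measured compounds is available for this assay, so nothing is known about how any change moves the read-out. Compound 3 `C=C[C@@](C)(/C=C/c1ccc(O)c(/C=C/C=C/c2ccccc2)c1)CCC=C(C)C` is the next entry. 2-phenylethenyl in place of benzyloxycarbonyl on a double-bonded chain carbon bound to a double-bonded chain carbon Both measured compounds sit at the same limit, so the data point in no direction. The step from compound 2 to compound 3 is expected to be a number no higher from compound 2 to compound 3 (the limit leaves the size open), which means none beyond the scatter. Compound 3 is estimated at 36600 nM in this assay, within 12000 nM to 110000 nM, and is expected most likely to be reported again only as a limit.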

Compound 3, half-maximal effective concentration: > 15000 nM
Compound 3 was reported as a limit (the forecaster's own chance of this, stated with the estimate: 85%); the middle value does not contradict the limit.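

In this assay compound 3 gives > 15000 nM, a limit and not a number. Compound 2 also stands only as a limit, so no step can be read from compound 2 to compound 3. The compounds shown leave open whether 2-phenylethenyl in place of benzyloxycarbonyl moves the read-out at all, and where any half-maximal concentration lies.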